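Methoxy in place of azido on a purine nucleoside core

The source may report more compounds than this note shows. Statements on the series, on what has been measured and on what is new or still open speak of the compounds shown alone.

In an ADME assay on CCRF-CEM cells (Homo sapiens) for cytotoxicity, read by trypan blue exclusion, with a stated time of 6 days (on this read-out lower numbers stand for higher toxicity in this test and higher numbers for lower toxicity in this test), the three measured compounds stand as follows.

Compound 1 `CC(C)(C)OC(=O)NOc1nc(N)nc2c1ncn2[C@@H]1O[C@H](CO)[C@@H](O)[C@@]1(C)O`: > 100000 nM
Compound 2 `COc1nc(Cl)nc2c1ncn2[C@@H]1O[C@H](CO)[C@@H](O)[C@@]1(C)O`: > 100000 nM
Compound 3 `C[C@@]1(O)[C@H](O)[C@@H](CO)O[C@H]1n1cnc2c(N)nc(N=[N+]=[N-])nc21`: > 100000 nM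

Each of these three results is a limit of the assay, not a number. For compound 3 in particular, the value > 100000 nM is such a limit, and it sits at the limit of > 100000 nM in this assay, at which 3 of the 3 values shown sit, the same place where the results of the other two compounds sit. Within the data shown here, no pair among the measured compounds differs in one place only, so no measured step is available to calibrate the change that leads to compound 4.

Compound 4 `COc1nc(N)c2ncn([C@@H]3O[C@H](CO)[C@@H](O)[C@@]3(C)O)c2n1` differs from compound 3 by methoxy in place of azido on an aromatic carbon. With every measured compound resting at the limit, the step that the limit leaves unreadable from compound 3 to compound 4 is expected to be none beyond the scatter, and compound 4 is most likely to be reported as a limit again. Compound 4 is expected at 150000 nM, within a range from 50000 nM to 500000 nM.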

Compound 4, half-maximal cytotoxic concentration: > 100000 nM
Compound 4: a limit, no number; the forecaster's own chance of this, stated with the estimate: 85%; the middle value does not contradict the limit.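

Among these compounds, compound 3 and compound 4 both rest at a limit rather than a number, so no step between them can be read. The compounds shown leave open how far beyond that limit each one lies in this assay, and what methoxy in place of azido changes there.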